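The source may report more compounds than this note shows. Statements on the series, on what has been measured and on what is new or still open speak of the compounds shown alone.

Measured so far in an ADME assay on microsomes from liver (Canis lupus familiaris) for metabolic stability; a lower number here means that the compound disappears faster, a higher number that the compound lasts longer:
- Compound 1 `Nc1nc(NCCNc2ncc(-c3ncc[nH]3)c(-c3ccc(Cl)cc3)n2)ccc1[N+](=O)[O-]`: > 0.5 h (a limit)
- Compound 2 `Nc1nc(NCCNc2ncc(-c3ncc[nH]3)c(-c3ccccc3Br)n2)ccc1[N+](=O)[O-]`: > 0.5 h (a limit)

Compound 2 has no exact number in this assay, only the limit > 0.5 h. Compound 3 `Nc1nc(NCCNc2ncc(-c3ncc[nH]3)c(-c3ccc(F)cc3F)n2)ccc1[N+](=O)[O-]` keeps the shared core and has 2,4-difluorophenyl in place of 2-bromophenyl on an aromatic carbon.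

Among the compounds with values here, one measured step bears on this change, as it also swaps the group at this place: a step that the two limits leave unreadable from compound 1 to compound 2. Its size cannot be read, so it does not show how far such a swap moves the half-life. The remaining guide is the limit of > 0.5 h in this assay, at which 2 of the 2 values shown sit. On that basis, no step beyond the usual scatter is expected, and no direction can be given. The expected step is a step that the limit leaves unreadable from compound 2 to compound 3, which is only an estimate. Compound 3 may well be reported as a limit too. For compound 3 the estimated half-life is 0.7 h, with an expected range from 0.4 h to 1.5 h.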

Compound 3, half-life: > 0.5 h
Compound 3: no number, only a limit; the forecaster's own chance of this, stated with the estimate: 80%; the middle value does not contradict the limit.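

Compound 1, compound 2 and compound 3 all carry only a limit in this assay, so no new step can be read among them: the limit of > 0.5 h in this assay, at which 3 of the 3 values shown sit.

The compounds shown leave open how long each one actually lasts, and whether 4-chlorophenyl, 2-bromophenyl or 2,4-difluorophenyl at this place makes any difference to the half-life.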